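The source may report more compounds than this note shows. Statements on the series, on what has been measured and on what is new or still open speak of the compounds shown alone.

Compound 1 `N#Cc1c(Cl)nc(SCc2nc3ccccc3[nH]2)nc1-c1ccccc1` is the reference point of this series. In a functional assay on KB cells (Homo sapiens) for cytotoxicity, read by MTT assay, with a stated time of 3 days (on this read-out lower numbers stand for stronger inhibition and higher numbers for weaker inhibition), compound 1 gives 3.7 nM, and it sits at the low end of the three numbers recorded so far. Compound 2 `CCNc1nc(SCc2nc3ccccc3[nH]2)nc(-c2ccccc2)c1C#N` gives 7.35 nM, a step of a 2.0-fold higher number from compound 1 to compound 2 (0.30 log units; within the scatter). Compound 3 `N#Cc1c(NC(N)=O)nc(SCc2nc3ccccc3[nH]2)nc1-c1ccccc1` gives 9.6 nM, a step of a 2.6-fold higher number from compound 1 to compound 3 (0.41 log units; beyond the scatter); between those two, the step is a 1.3-fold higher number from compound 2 to compound 3 (0.12 log units; within the scatter).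

Compound 4 `CN1CCN(c2nc(SCc3nc4ccccc4[nH]3)nc(-c3ccccc3)c2C#N)CC1` differs from compound 1 in one place: 4-methylpiperazin-1-yl in place of chloro on an aromatic carbon. For the measured compounds named here, the steps that bear on this change are the two other replacements of the chloro group on the same aromatic carbon, each by a nitrogen-linked group: a 2.0-fold higher number from compound 1 to compound 2 (0.30 log units; within the scatter) and a 2.6-fold higher number from compound 1 to compound 3 (0.41 log units; beyond the scatter). Both moved the number upward, one within the scatter and one modestly beyond it. On that basis a small rise is expected for compound 4, on the order of a 2.2-fold higher number from compound 1 to compound 4 (0.33 log units; beyond the scatter), and the value of compound 4 in this assay is estimated at 8 nM, with a range from 3 nM to 22 nM.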

Compound 4, half-maximal inhibitory concentration: 2.7 nM
For compound 4 the middle estimate is 3.0-fold (0.47 log units) above the measured one; measured number below the stated range.
By their numbers in this assay, from the lowest: compounds 4, 1, 2 and 3 (each within the scatter of the next, the first and the last beyond it).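

With a group of 7 heavy atoms in place of a single chlorine on this aromatic carbon, the number in this assay cannot be told apart from that of compound 1 (a 1.4-fold lower number from compound 1 to compound 4 (0.14 log units; within the scatter)). Among the groups linked through nitrogen, 4-methylpiperazin-1-yl is set apart from both ureido (a 3.6-fold lower number from compound 3 to compound 4 (0.55 log units; beyond the scatter)) and ethylamino (a 2.7-fold lower number from compound 2 to compound 4 (0.43 log units; beyond the scatter)), so the nitrogen link alone does not fix the number at this position. No measurement at hand explains why these groups differ.

As far as these compounds go, what a morpholine or a piperazine without its methyl group would give at this carbon remains open. So does whether the six-membered non-aromatic ring or its second nitrogen accounts for the gap to compound 2 and compound 3.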